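Cyclohexylmethyl to benzyl on the dipropyl core

The source may report more compounds than this note shows. Statements on the series, on what has been measured and on what is new or still open speak of the compounds shown alone.

Within the data shown here, the three measured members share one bicyclic core and differ at one ring carbon and at the two ring nitrogens that carry alkyl groups. Among the measured compounds shown here, compound 1 `Cn1c(=O)c2nc(-c3ccc(Cl)cc3)[nH]c2n(C)c1=O` gives 0.646 nM in an assay on isolated protein for binding affinity to adenosine receptor A1 (Rattus norvegicus) (a higher number here means a weaker inhibitor, a lower number a stronger inhibitor), and compound 2 `Cc1ccc(-c2nc3c(=O)n(C)c(=O)n(C)c3[nH]2)cc1` gives 0.513 nM; the only single-point step, a 1.3-fold lower number from compound 1 to compound 2 (0.10 log units; within the scatter), is flat. Compound 3 `CCCn1c(=O)c2nc(CC3CCCCC3)[nH]c2n(CCC)c1=O`, with propyl groups on both nitrogens and a cyclohexylmethyl group, stands highest of the three numbers at 38.9 nM, far from both of the others.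

Compound 4 `CCCn1c(=O)c2nc(Cc3ccccc3)[nH]c2n(CCC)c1=O` is the next member, made from compound 3 by phenyl in place of cyclohexyl on a saturated chain carbon bound to an aromatic carbon. For the measured compounds named here, no measured step covers a saturated ring giving way to an aromatic ring; the step from compound 1 to compound 2 concerns a substituent on an aromatic ring of a different core and bears on this change only in showing that small changes at the far end of that group left the number unmoved. Compounds 1 and 2 carry their aromatic rings directly on the core and differ from compound 3 in several places, so their low values set no scale for compound 4. The estimate for compound 4 is therefore anchored on compound 3, with a modest step of a 2.3-fold higher number from compound 3 to compound 4 (0.36 log units; beyond the scatter) expected, and the number expected at 90 nM, within 25 nM to 350 nM.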

Compound 4, inhibition constant: 891 nM
For compound 4 the middle estimate is 9.9-fold (1.00 log units) below the measured one; the whole stated range lies below it.
By their numbers in this assay, from the lowest: compounds 2 and 1 (each within the scatter of the next); then compound 3; then compound 4.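

In this assay, phenyl in place of cyclohexyl on a saturated chain carbon bound to an aromatic carbon is a large step on the dipropyl core (a 23-fold higher number from compound 3 to compound 4 (1.36 log units; beyond the scatter)), so the number at this position responds strongly to whether the ring is aromatic. Among these compounds, the group's heavy-atom count and its counts of hydrogen-bond donors and acceptors stay the same across the change, which the earlier compounds could not show: their one single-point step, methyl in place of chloro on an aromatic carbon, lies within the scatter and leaves the ring itself untouched. No measurement shown here bears on why the number moves.

Going by these compounds, the pair of compound 3 and compound 4 is a single comparison on one core, so it remains open whether the same change gives a step of similar size with methyl groups on both ring nitrogens in place of propyl. Also open, on these data alone, is how the number responds at this position to a chloro or methyl group on the phenyl ring of the benzyl, to a cyclopentylmethyl group, or to a longer chain between the ring and the core.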